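Replacing an open side chain with 3,3-dimethyloxiran-2-yl

The source may report more compounds than this note shows. Statements on the series, on what has been measured and on what is new or still open speak of the compounds shown alone.

Compound 1 `C=CC(C)(O)CC[C@@H]1C(=C)CC[C@H](Br)[C@@]1(C)CCC(O)C(C)(C)Cl`: 71500 nM
Compound 2 `C=CC(C)(O)CC[C@@H]1C(=C)CC[C@H](Br)[C@@]1(C)CCC(OC)C(C)(C)O`: > 100000 nM

Both compounds were tested in a functional assay on MCF7 cells (Homo sapiens) for cytotoxicity, read by MTT assay, with a stated time of 48 h; on this read-out higher numbers stand for weaker inhibition and lower numbers for stronger inhibition. In this assay compound 2 gives > 100000 nM, which is a limit and not a number. Compound 2 thus stands at the limit of > 100000 nM in this assay, at which 1 of the 2 values shown sits.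

Compound 3 `C=CC(C)(O)CC[C@@H]1C(=C)CC[C@H](Br)[C@@]1(C)CCC1OC1(C)C` keeps the shared core, but its open side chain gives way to a three-membered ring: 3,3-dimethyloxiran-2-yl in place of 2-hydroxy-1-methoxy-2-methylpropyl on a saturated chain carbon, two bonds along the chain from a saturated ring carbon.

For the measured compounds named here, one measured step bears on this change, since it also alters this side chain: an at least 1.3-fold higher number from compound 1 to compound 2 (0.14 log units; that floor lies within the scatter). That step gives only a floor, and the floor lies within the scatter. Going by the values given here, compound 1 gives 71500 nM, the only true number here, so the expectation is anchored to it. The expected step is modest and is estimated to run toward a lower number: an at least 1.4-fold lower number from compound 2 to compound 3 (0.15 log units; that floor lies within the scatter). Compound 3 is estimated at 70000 nM (range 30000 nM to 150000 nM).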

Compound 3, half-maximal inhibitory concentration: 71700 nM
Estimate against measurement, compound 3: 1.0-fold (0.01 log units) below; the measured number falls inside the stated range.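

With compound 3, a second true number joins the series in this assay, and the 3,3-dimethyloxiran-2-yl ring can be read directly against the open 2-chloro-1-hydroxy-2-methylpropyl chain, where the two cannot be told apart: a 1.0-fold higher number from compound 1 to compound 3 (0.00 log units; within the scatter). The comparison with the 2-hydroxy-1-methoxy-2-methylpropyl chain gives only a floor, not a size: an at least 1.3-fold lower number from compound 2 to compound 3 (0.14 log units; that floor lies within the scatter). Compound 2 holds a limit and not a number: the limit of > 100000 nM in this assay, at which 1 of the 3 values shown sits.

As far as these compounds go, how far compound 2 truly lies from compound 3 stays open, so the methoxy chain cannot yet be placed relative to the ring. Also open, from the compounds shown here alone, is whether an amine, a carboxylic acid or a longer chain on this saturated chain carbon would move the number beyond the scatter.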